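The source may hold more compounds than are shown below. What is called first, only, known or untested is meant among the compounds shown, and "the series" means these compounds.

Working notes on a small series run in a functional assay on MCF7 cells (Homo sapiens) for inhibition, read by sulforhodamine B assay, with a stated time of 72 h; a higher number here means a weaker inhibitor, a lower number a stronger inhibitor. Compound 1 `CC(c1ccc(-c2ccccc2)c(F)c1)c1nnc2n1N=C(c1ccc(Cl)cc1Cl)CS2` gives 7600 nM in this assay and stands lowest of the two numbers on hand. Compound 2 `COc1ccc2cc(C(C)c3nnc4n3N=C(c3ccc(F)cc3)CS4)ccc2c1` gives 15800 nM in this assay, above compound 1 by a margin beyond the usual scatter; the two differ at more than one place, so the gap cannot be tied to any single change. Compound 3 `CC(c1ccc(-c2ccccc2)c(F)c1)c1n[nH]c(=S)n1N` is reported in this assay as "not active" (no number reported), with no number given.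

Compound 4 `CC(c1ccc(-c2ccccc2)c(F)c1)c1nnc2n1N=C(c1ccc(Br)cc1)CS2` is not yet measured. It differs from compound 1 by 4-bromophenyl in place of 2,4-dichlorophenyl on a carbon with a double bond to nitrogen, in words 4-bromophenyl in place of 2,4-dichlorophenyl on a carbon with a double bond to nitrogen. Among the compounds with values here, no pair of measured compounds shows this change alone, so there is no step to anchor it; the aryl group at the same place in compound 2 sits on a different remainder and does not separate the two changes. Within the data shown here, the expected step of a 1.3-fold higher number from compound 1 to compound 4 (0.12 log units; within the scatter) is small, within the scatter or a little toward a weaker inhibitor, since the only compound with a single halogen on that ring, compound 2, gave the higher number 15800 nM. Compound 4 is estimated at 10000 nM, with a range from 4000 nM to 30000 nM.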

Compound 4, half-maximal inhibitory concentration: 7400 nM
Beside the measured number, compound 4's estimate is 1.4-fold (0.13 log units) above it; the range from low to high includes it.
By their numbers in this assay, from the lowest: compounds 4 and 1 (each within the scatter of the next); then compound 2.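

Within the data shown here, with 4-bromophenyl in place of 2,4-dichlorophenyl on a carbon with a double bond to nitrogen, the step is a 1.0-fold lower number from compound 1 to compound 4 (0.01 log units; within the scatter) in this assay, which gives the first reading of this position with the rest of the molecule held fixed. The two aryl groups cannot be told apart in this assay on the core of compound 1, so this exchange, which removes both chlorines and brings in one bromine, leaves the number within the scatter. No measurement on hand accounts for this lack of separation.

Going by these compounds, it remains open whether the position stays this insensitive when the aryl group carries something other than halogen, such as an amine or a carboxylic acid on the phenyl ring, or when the aryl group gives way to a longer alkyl chain. On these data alone, it is also open whether the same exchange would read the same way on the remainder of compound 2, where the change at this position has no matched partner.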